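This account rests on a few compounds, and the source may have more. Where it says the series, first, only, none or still open, it means among the compounds named here.

Working notes on the series. In a functional assay on OVCAR-8 cells (Homo sapiens) for inhibition, read by sulforhodamine B assay, with a stated time of 48 h (on this read-out lower numbers stand for stronger inhibition of growth and higher numbers for weaker inhibition of growth), compound 1 `COc1cc(-c2nn(-c3cccc(NC(=O)c4cccc(C(F)(F)F)c4)c3)cc2-c2ccncc2)ccc1Cl` gives 2000 nM, compound 2 `COc1cc(-c2nn(-c3cccc(NC(=O)Nc4cccc(C(F)(F)F)c4)c3)cc2-c2ccncc2)ccc1Cl` gives 739 nM and compound 3 `COc1cc(-c2nn(-c3cccc(NC(=O)c4ccc(Cl)c(C(F)(F)F)c4)c3)cc2-c2ccncc2)ccc1Cl` gives 3350 nM. Compound 3 is separated clearly only by a 4.5-fold higher number from compound 2 to compound 3 (0.66 log units; beyond the scatter). Compound 3 and compound 1 are level within the scatter.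

Compound 4 `COc1cc(-c2nn(-c3cccc(NC(=O)c4ccccc4)c3)cc2-c2ccncc2)ccc1Cl` follows from phenyl in place of 4-chloro-3-(trifluoromethyl)phenyl on a carbonyl carbon, with phenyl in place of 4-chloro-3-(trifluoromethyl)phenyl on a carbonyl carbon. Only the loss of chloro has a measured counterpart, a 1.7-fold higher number from compound 1 to compound 3 (0.22 log units; within the scatter), and that step runs the opposite way, chloro in place of hydrogen, and stays within the scatter. For the measured compounds named here, the loss of trifluoromethyl has no measured step in this set, so the estimate carries a wide margin. The other step, a 2.7-fold lower number from compound 1 to compound 2 (0.43 log units; beyond the scatter), concerns the amino swap on the carbonyl carbon and does not bear on this change.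

No step beyond the scatter is therefore expected in this assay, in either direction. The expected move is a 1.1-fold lower number from compound 3 to compound 4 (0.05 log units; within the scatter). Compound 4 is estimated at 3000 nM, with an expected range of 1100 nM to 8000 nM.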

Compound 4, concentration for 50% growth inhibition: 995 nM
The estimate for compound 4 lay 3.0-fold (0.48 log units) above the measured number, outside the stated range (below it).
By their numbers in this assay, from the lowest: compounds 2, 4, 1 and 3 (each within the scatter of the next, the first and the last beyond it).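

For the compounds shown here, on the carbonyl carbon, in this assay, the full change from 4-chloro-3-(trifluoromethyl)phenyl to phenyl gives a 3.4-fold lower number from compound 3 to compound 4 (0.53 log units; beyond the scatter) and so shows that the unsubstituted phenyl keeps growth inhibition, which the earlier compounds could not show. Compound 4 also stands level with its two other neighbours, with a 2.0-fold lower number from compound 1 to compound 4 (0.30 log units; within the scatter) for hydrogen in place of trifluoromethyl and a 1.3-fold higher number from compound 2 to compound 4 (0.13 log units; within the scatter) for phenyl in place of (3-(trifluoromethyl)phenyl)amino, so only compound 3 is clearly separated from it. No measurement at hand accounts for these results.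

From the compounds shown here alone, whether a phenyl ring on this carbonyl carbon carrying an amine or a carboxylic acid would separate from compound 4 stays open. Equally open, going by these compounds, is how an unsubstituted phenylamino group would read in this position.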